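Chloro-to-methyl exchange on the benzamide ring of compound 1

A few compounds are considered here, and "the series" means these few. Any claim that something is new, unique, unknown or untested is made for them only; others in the source may bear on it.

Measured compounds:
compound 1 `O=C(c1cc(Cl)ccc1-c1ncccn1)N1CC2(CC2)C[C@H]1CNc1cc(C(F)(F)F)ccn1` — 7.1
compound 2 `Cc1ccc(-c2ncccn2)c(C(=O)N2CCC3(CC3)C[C@H]2CNc2ccc(Cl)cn2)c1` — < 5
compound 3 `Cc1nc(C(=O)N2CCC3(CC3)C[C@H]2CNc2ccc(Cl)cn2)c(-c2ccccc2)s1` — < 5

For the measured compounds named here, in a functional assay on HEK293 cells for antagonist activity at Orexin receptor type 2 (Homo sapiens), read by FLIPR and calcium flux (on this read-out higher numbers stand for higher potency (the scale is a negative logarithm) and lower numbers for lower potency), compound 1 gives 7.1, the only number among the three values shown. Compound 2 comes out at < 5, a limit of the assay and not a number. Compound 3 likewise sits at the limit with < 5. Both of these compounds differ from compound 1 in more than one place, so their values say nothing about any single change; they only show that two of the three values shown sit at the limit (the limit of < 5 in this assay, at which 2 of the 3 values shown sit).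

Compound 4 `Cc1ccc(-c2ncccn2)c(C(=O)N2CC3(CC3)C[C@H]2CNc2cc(C(F)(F)F)ccn2)c1` is not yet measured. It keeps the core of compound 1 and differs from it by methyl in place of chloro on an aromatic carbon. Going by the values given here, no single-change step between measured compounds is available for this exchange, so the size of the step from compound 1 to compound 4 in this assay is not known from the data.

For compound 4 an estimated step of a number 0.30 log units lower from compound 1 to compound 4 (within the scatter) is expected, a modest loss that may still lie within the scatter. Compound 4 is therefore estimated at 6.8, expected between 6 and 7.5.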

Compound 4, negative logarithm of the antagonist equilibrium constant: 7.8
The estimate for compound 4 lay 1.00 log units below the measured number, outside the stated range (above it).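

Working notes on the exchange at this position. In this assay methyl in place of chloro, para to the pyrimidin-2-yl group, gives a gain beyond the scatter (a number 0.70 log units higher from compound 1 to compound 4 (beyond the scatter)). For the compounds shown here, this is the only single-change step, and it shows that chloro is not needed here for potency on the shared core and that this position responds measurably to a swap of one heavy atom for another. Going by these compounds alone, nothing measured so far bears on the reason for this step.

Going by these compounds, the step rests on one pair, so whether the gain from methyl carries over to a different amine side of the molecule, or is tied to the trifluoromethyl-bearing partner present in compound 1 and compound 4, remains open. Also open, on these data alone, is how a bare hydrogen, a methoxy, a nitrile or an ethyl group at the same aromatic carbon would compare with methyl, and thus whether the trend continues with a longer chain or turns back.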